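The source may report more compounds than this note shows. Statements on the series, on what has been measured and on what is new or still open speak of the compounds shown alone.

In a functional assay, with a stated time of 90 s (a lower number here means a stronger inhibitor, a higher number a weaker inhibitor), compound 3 `Cc1nc2c3ccccc3ccc2c2nc3c(ccc4ccccc43)c(C)c12` gives 195 ug/mL, the highest of the three numbers in hand, though all three lie within the scatter of one another: compound 2 `Cc1nc2c3ccccc3ccc2c2nc3c(ccc4ccccc43)c(-c3ccccc3S)c12` gives 158 ug/mL and compound 1 `Cc1nc2c3ccccc3ccc2c2nc3c(ccc4ccccc43)c(-c3nccnc3N)c12` gives 134 ug/mL. Compound 4 `Cc1nc2c3ccccc3ccc2c2nc3c(ccc4ccccc43)c(-c3ccccc3)c12` differs from compound 3 by phenyl in place of methyl on an aromatic carbon. Among the measured compounds shown here, the steps that bear on an exchange at this aromatic carbon are a 1.2-fold higher number from compound 2 to compound 3 (0.09 log units; within the scatter) and a 1.5-fold higher number from compound 1 to compound 3 (0.16 log units; within the scatter), both within the scatter, and the remaining step of a 1.2-fold higher number from compound 1 to compound 2 (0.07 log units; within the scatter) is just as small. Nothing in these numbers points to a step beyond the scatter, so the expected change is a 1.1-fold lower number from compound 3 to compound 4 (0.05 log units; within the scatter), in effect none. On this basis compound 4 is estimated at 175 ug/mL in this assay, with a range from 90 ug/mL to 340 ug/mL.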

Compound 4, half-maximal inhibitory concentration: 188 ug/mL
Compound 4: middle estimate off by 1.1-fold (0.03 log units), on the low side; measured number inside the range.
By their numbers in this assay, from the lowest: compounds 1, 2, 4 and 3 (each within the scatter of the next).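

In this assay, at this aromatic carbon opposite the ring nitrogen, phenyl in place of methyl gives a 1.0-fold lower number from compound 3 to compound 4 (0.02 log units; within the scatter), so one six-membered aromatic ring of carbon only leaves the number within the scatter. Hydrogen in place of sulfanyl on that ring gives a 1.2-fold higher number from compound 2 to compound 4 (0.08 log units; within the scatter), and phenyl in place of 3-aminopyrazin-2-yl gives a 1.4-fold higher number from compound 1 to compound 4 (0.15 log units; within the scatter), so neither the sulfanyl nor the aminopyrazine separates from plain phenyl here. No measured evidence bears on this result. As far as these compounds go, whether a carboxylic acid, a basic aliphatic amine or a longer alkyl chain at this carbon would give a step beyond the scatter remains open.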